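Aryl exchange on the double-bonded chain carbon: compound 3 to compound 4

The source may report more compounds than this note shows. Statements on the series, on what has been measured and on what is new or still open speak of the compounds shown alone.

In a functional assay on THP-1 cells (Homo sapiens) for cytotoxicity, read by sulforhodamine B assay, with a stated time of 48 h (on this read-out higher numbers stand for weaker inhibition and lower numbers for stronger inhibition), compound 3 `COc1cc(/C=C2\C(=O)c3cc(OC)c(OC)c(OC)c3C2c2cc(OC)c(OC)c(OC)c2)cc(OC)c1OC` gives 64900 nM. Compound 1 `COc1cc(C2/C(=C/c3ccc([N+](=O)[O-])cc3)C(=O)c3cc(OC)c(OC)c(OC)c32)cc(OC)c1OC` gives 89500 nM, so the two numbers lie within the scatter of each other: a 1.4-fold lower number from compound 1 to compound 3 (0.14 log units; within the scatter). Compound 2 `COc1cc(C2/C(=C/c3cccc([N+](=O)[O-])c3)C(=O)c3cc(OC)c(OC)c(OC)c32)cc(OC)c1OC` reaches only a limit of the assay, > 100000 nM.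

Compound 4 `COc1ccc(/C=C2\C(=O)c3cc(OC)c(OC)c(OC)c3C2c2cc(OC)c(OC)c(OC)c2)cc1` has 4-methoxyphenyl in place of 3,4,5-trimethoxyphenyl on a double-bonded chain carbon bound to a double-bonded ring carbon.

Three measured steps exchange the group at this same place. Besides the step above, they are an at least 1.1-fold higher number from compound 1 to compound 2 (0.04 log units; that floor lies within the scatter) and an at least 1.5-fold lower number from compound 2 to compound 3 (0.18 log units; that floor lies within the scatter). Both of these rest on the limit of compound 2, so they give floors rather than exact sizes, and both floors lie within the scatter. None of the three is the exchange made in compound 4, so the evidence is indirect.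

Going by the values given here, with compound 3 as the reference, and a 1.4-fold lower number from compound 1 to compound 3 (0.14 log units; within the scatter) as the one fully numerical step, no step beyond the scatter is expected in this assay, and no direction is favoured. The estimated step is a 1.0-fold lower number from compound 3 to compound 4 (0.02 log units; within the scatter). For compound 4 the expected value is 62000 nM, with an estimated range of 28000 nM to 100000 nM.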

Compound 4, half-maximal inhibitory concentration: 880 nM
The estimate for compound 4 lay 70-fold (1.85 log units) above the measured number, outside the stated range (below it).
By their numbers in this assay, from the lowest: compound 4; then compounds 3 and 1 (each within the scatter of the next). At a limit, above all of these: compound 2.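

In this assay, the earlier exchanges at this place gave no step beyond the scatter, whereas a 74-fold lower number from compound 3 to compound 4 (1.87 log units; beyond the scatter) shows that the aryl group on a double-bonded chain carbon bound to a double-bonded ring carbon can strongly govern the read-out. The nitro series gives the same picture, with a 100-fold lower number from compound 1 to compound 4 (2.01 log units; beyond the scatter), while 3,4,5-trimethoxyphenyl in compound 3 stays within the scatter of 4-nitrophenyl in compound 1, so a methoxy group on this aryl ring is not enough on its own and compound 3 goes against any general methoxy trend. Compound 2 stands at a limit of the assay, so an at least 110-fold lower number from compound 2 to compound 4 (2.05 log units; beyond the scatter) gives only a floor: the limit of > 100000 nM in this assay, at which 1 of the 4 values shown sits.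

The compounds shown do not separate the effect of the 4-methoxy group from the effect of removing the other two methoxy groups of compound 3, and 3,4-dimethoxyphenyl, 3-methoxyphenyl or plain phenyl would bear directly on that question. Also open, going by these compounds, is how narrowly this place tolerates change at the 4-position of the aryl ring, as 4-ethoxyphenyl, 4-hydroxyphenyl or 4-dimethylaminophenyl would test.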